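Amide Variation on a Shared Core in Mice

A few compounds are considered here, and "the series" means these few. Any claim that something is new, unique, unknown or untested is made for them only; others in the source may bear on it.

Of the compounds shown here, three built on one shared core have been measured in a functional assay on the whole organism with Mus musculus as the target; on this read-out higher numbers stand for an effect only at larger amounts of compound and lower numbers for an effect already at smaller amounts. Compound 1 `CCN(CC)C(=O)Cn1c(-c2ccc(Cl)cc2)nc2cccnc21` gives 16 mg/kg, compound 2 `CCCN(CCC)C(=O)Cn1c(-c2ccc(Cl)cc2)nc2cccnc21` gives 11 mg/kg, and compound 3 `O=C(Cn1c(-c2ccc(Cl)cc2)nc2cccnc21)N1CCOCC1` gives 11.5 mg/kg. Compound 3 stands second highest of the three numbers, yet a 1.4-fold lower number from compound 1 to compound 3 (0.14 log units; within the scatter) and a 1.0-fold higher number from compound 2 to compound 3 (0.02 log units; within the scatter) both lie within the scatter, as does a 1.5-fold lower number from compound 1 to compound 2 (0.16 log units; within the scatter), so the three compounds cannot be told apart on this read-out.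

Compound 4 `CN(C)CCNC(=O)Cn1c(-c2ccc(Cl)cc2)nc2cccnc21` differs from compound 3 in a single place: (2-(dimethylamino)ethyl)amino in place of morpholin-4-yl on a carbonyl carbon. All three measured steps concern the same position on the carbonyl carbon, and none of them moved the number beyond the scatter. Within the data shown here, the new group carries a hydrogen-bond donor that the earlier groups lack, but the data hold no step that tests such a group. Compound 4 is therefore expected to give 11.5 mg/kg in this assay, with a range from 5.5 mg/kg to 24 mg/kg. The step this estimate means is no change at the digits printed from compound 3 to compound 4 (within the scatter), no change beyond the scatter.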

Compound 4, dose for half-maximal effect: 62 mg/kg
Compound 4: middle estimate off by 5.4-fold (0.73 log units), on the low side; measured number above the stated range.
By their numbers in this assay, from the lowest: compounds 2, 3 and 1 (each within the scatter of the next); then compound 4.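

In this assay the group on the carbonyl carbon does matter, since all three steps lie beyond the scatter (in turn a 5.4-fold higher number from compound 3 to compound 4 (0.73 log units; beyond the scatter) and a 5.6-fold higher number from compound 2 to compound 4 (0.75 log units; beyond the scatter) and a 3.9-fold higher number from compound 1 to compound 4 (0.59 log units; beyond the scatter)), whereas the exchanges among the earlier groups did not. Morpholin-4-yl and (2-(dimethylamino)ethyl)amino have the same count of heavy atoms, so this change does not alter that count; it does remove the ring, add the amide hydrogen and replace the ring oxygen's place in the count with a second nitrogen, all in one step. Nothing available explains the higher number or separates these changes from one another.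

The compounds shown leave open whether the amide hydrogen or the terminal dimethylamino group goes with the step. A plain propylamino group would carry the hydrogen without the terminal amine, and a 2-(dimethylamino)ethyl group on an N-methyl amide would carry the amine without the hydrogen.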